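FAAH inhibition: from chlorophenyl to dimethylsulfamoylphenyl on the tetrazole

A few compounds are considered here, and "the series" means these few. Any claim that something is new, unique, unknown or untested is made for them only; others in the source may bear on it.

Measured compounds:
compound 1, `CCCCCCCCc1ccc(OCC(=O)Cn2nnnc2-c2ccccc2)cc1`, 71 nM
compound 2, `CCCCCCCCc1ccc(OCC(=O)Cn2nnnc2-c2ccccc2Cl)cc1`, 4600 nM

For the measured compounds named here, in an assay on microsomes from brain for inhibition of Fatty-acid amide hydrolase 1 (Rattus norvegicus), read by fluorescence and HPLC, with a stated time of 60 min (on this read-out higher numbers stand for weaker inhibition and lower numbers for stronger inhibition), compound 2 gives the higher of the two numbers, so it is the weaker inhibitor; the nearest measured neighbour is compound 1, and the only measured step is a 65-fold higher number from compound 1 to compound 2 (1.81 log units; beyond the scatter). Compound 3, `CCCCCCCCc1ccc(OCC(=O)Cn2nnnc2-c2cccc(S(=O)(=O)N(C)C)c2)cc1`, carries a different aryl group on the tetrazole: 3-(dimethylsulfamoyl)phenyl in place of 2-chlorophenyl on an aromatic carbon. Going by the values given here, the one step that bears on this change runs from the unsubstituted phenyl to the 2-chlorophenyl, and it was large. Among the compounds with values here, no measured pair shows the move from a 2-chlorophenyl to an aryl bearing a sulfamoyl group, so the direction for compound 3 rests on that single step alone. Compound 3 is expected to sit between the two measured numbers, with a step of a 9.2-fold lower number from compound 2 to compound 3 (0.96 log units; beyond the scatter). The estimate for compound 3 in this assay is 500 nM, within a range from 50 nM to 5000 nM.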

Compound 3, half-maximal inhibitory concentration: 1900 nM
For compound 3 the middle estimate is 3.8-fold (0.58 log units) below the measured one; the measured number falls inside the stated range.
By their numbers in this assay, from the lowest: compound 1; then compound 3; then compound 2.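

In this assay, a second substituent on the phenyl also weakens inhibition, with a 27-fold higher number from compound 1 to compound 3 (1.43 log units; beyond the scatter), so the loss is not confined to the chloro group. The larger 3-(dimethylsulfamoyl)phenyl, with 12 heavy atoms against 7 and 2 hydrogen-bond acceptors against 0, nonetheless does modestly better than 2-chlorophenyl, with a 2.4-fold lower number from compound 2 to compound 3 (0.38 log units; beyond the scatter), and the unsubstituted phenyl of compound 1 remains the best of the three. Nothing measured here accounts for these steps.

Compound 2 and compound 3 differ both in the substituent and in where it sits on the phenyl, so the compounds shown cannot separate these two changes. On these data alone, whether a small methoxy group, an amine or a carboxylic acid on the phenyl would also weaken inhibition remains open.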